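This account rests on a few compounds, and the source may have more. Where it says the series, first, only, none or still open, it means among the compounds named here.

In a functional assay on B16 cells (Mus musculus) for inhibition, with a stated time of 72 h (a higher number here means a weaker inhibitor, a lower number a stronger inhibitor), compound 1 `Cc1ccc(CN2CCNC2=S)cc1` gives 4800 nM and compound 2 `S=C1NCCN1Cc1ccc(Cl)cc1` gives 4300 nM. The step of a 1.1-fold lower number from compound 1 to compound 2 (0.05 log units; within the scatter) corresponds to chloro in place of methyl on an aromatic carbon. Compound 3 `Cc1ccc(CN2CCCNC2=S)cc1` gives 5100 nM in this assay; the difference between the core of compound 3 and the core of compound 1 is not broken down here. Compound 4 `S=C1NCCCN1Cc1ccc(Cl)cc1` has not yet been measured in this assay. It differs from compound 3 by chloro in place of methyl on an aromatic carbon, the same kind of change as from compound 1 to compound 2, though the place differs: para to a group of 8 heavy atoms here, para to a group of 7 heavy atoms there. For compound 4 a step of a 1.1-fold lower number from compound 3 to compound 4 (0.04 log units; within the scatter) is expected, resting on the step of a 1.1-fold lower number from compound 1 to compound 2 (0.05 log units; within the scatter) seen between compound 1 and compound 2. Compound 4 is estimated at 4600 nM, expected between 2300 nM and 9200 nM.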

Compound 4, half-maximal inhibitory concentration: 2400 nM
Compound 4: middle estimate off by 1.9-fold (0.28 log units), on the high side, within the range that was stated.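

Chloro in place of methyl on an aromatic carbon gives a 2.1-fold lower number from compound 3 to compound 4 (0.33 log units; beyond the scatter) in this assay. Set beside the earlier step on the other core, the new step does not separate from it: the same change on two cores in this assay, a 1.1-fold lower number (0.05 log units; within the scatter) from compound 1 to compound 2 and a 2.1-fold lower number (0.33 log units; beyond the scatter) from compound 3 to compound 4, 1.9-fold (0.28 log units) apart, within the scatter of two such steps. This fits the change carrying from the core of compound 1 to the core of compound 3 with no difference that can be told apart, but it does not show that the size of the step is the same on both cores, and two pairs give no general rule for the series.

The compounds shown carry only methyl or chloro on the aromatic ring, so the effect of a nitrile, an amine or a carboxylic acid on that same aromatic carbon remains open. From the compounds shown here alone, whether the step holds on a third core also remains open.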